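The source may hold more compounds than are shown below. What is called first, only, known or untested is meant among the compounds shown, and "the series" means these compounds.

Measured compounds:
Compound 1, `CCN(Cc1ccc2nc(C)[nH]c(=O)c2c1)c1ccc(C(=O)N[C@@H](CCC(=O)O)C(=O)O)c(C)c1`: 1200 nM in a functional assay on L1210 cells (Mus musculus) for inhibition; on this read-out higher numbers stand for weaker inhibition and lower numbers for stronger inhibition
Compound 2, `CCN(Cc1ccc2nc(C)[nH]c(=O)c2c1)c1ccc(C(=O)N[C@@H](CCC(=O)O)C(=O)O)c(F)c1`: 65 nM
Compound 3, `Cc1nc2ccc(CN(C)c3ccc(C(=O)N[C@@H](CCC(=O)O)C(=O)O)c(F)c3)cc2c(=O)[nH]1`: 19 nM

Of the compounds shown here, three have been measured in this assay, and compound 4, `Cc1nc2ccc(CN(C)c3ccc(C(=O)N[C@@H](CCC(=O)O)C(=O)O)c(C)c3)cc2c(=O)[nH]1`, has not. Compound 3 gives the lowest number of the three, and the step from compound 3 to compound 2 lies beyond the scatter, as does the step to compound 1.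

Compound 2 and compound 3 differ in their cores by hydrogen in place of methyl on a saturated chain carbon bound to a nitrogen on an aromatic ring, and this difference gave a 3.4-fold lower number from compound 2 to compound 3 (0.53 log units; beyond the scatter). Compound 4 is related to compound 3 in the same way that compound 1 is related to compound 2: the difference from compound 3 to compound 4 is methyl in place of fluoro on an aromatic carbon, and the difference from compound 2 to compound 1 is methyl in place of fluoro on an aromatic carbon. The two place descriptions agree word for word, so this is the same change made on two cores that differ by the difference just told. On the core of compound 2 it gave an 18-fold higher number from compound 2 to compound 1 (1.27 log units; beyond the scatter), a large step.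

For the measured compounds named here, since the same change is made at the same kind of place, a step of similar size is expected from compound 3 to compound 4, namely an 18-fold higher number from compound 3 to compound 4 (1.25 log units; beyond the scatter), resting on the single precedent an 18-fold higher number from compound 2 to compound 1 (1.27 log units; beyond the scatter) and on the value of compound 3, 19 nM. Going by the values given here, with only one earlier instance, the size of the step is uncertain, and the expected range is set wide. Compound 4 is therefore estimated at 340 nM, with a likely range from 110 nM to 1100 nM.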

Compound 4, half-maximal inhibitory concentration: 800 nM
Compound 4: middle estimate off by 2.4-fold (0.37 log units), on the low side, and the stated range covers the measured number.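

In this assay, methyl in place of fluoro on an aromatic carbon gave a 42-fold higher number from compound 3 to compound 4 (1.62 log units; beyond the scatter), again a large step, and its size carried over from one core to the other: the same change on two cores in this assay, an 18-fold higher number (1.27 log units; beyond the scatter) from compound 2 to compound 1 and a 42-fold higher number (1.62 log units; beyond the scatter) from compound 3 to compound 4, 2.3-fold (0.36 log units) apart, within the scatter of two such steps

The second change, hydrogen in place of methyl on a saturated chain carbon bound to a nitrogen on an aromatic ring, gave a 1.5-fold lower number from compound 1 to compound 4 (0.18 log units; within the scatter); this step is not separable from the scatter on its own, yet it also cannot be told apart from the step seen on the cores with fluoro: the same change on two cores in this assay, a 3.4-fold lower number (0.53 log units; beyond the scatter) from compound 2 to compound 3 and a 1.5-fold lower number (0.18 log units; within the scatter) from compound 1 to compound 4, 2.3-fold (0.36 log units) apart, within the scatter of two such steps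

These two pairs show that, on the cores at hand, each change kept its step within the scatter, but two cores are a narrow base, so they do not show that either step would hold on other cores of the series, and they say nothing about why the steps have these sizes.

The compounds shown leave open what hydrogen, chloro or methoxy would give on the same aromatic carbon, since only fluoro and methyl appear there. They also leave open how a longer chain such as propyl, or hydrogen, on the nitrogen that carries the methyl or ethyl group would behave alongside either of those two groups.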